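Swapping methyl for trifluoromethyl on a cytotoxic anilino scaffold

The source may hold more compounds than are shown below. What is called first, only, known or untested is meant among the compounds shown, and "the series" means these compounds.

Compound 2 `Cc1ccc(Nc2nccc(-c3c(C)nc4ccccn34)n2)cc1` gives the highest of three numbers in a functional assay on U-251 cells (Homo sapiens) for cytotoxicity, read by sulforhodamine B assay, with a stated time of 48 h, tested at 50 uM (a higher number here means more inhibition at the concentration tested (going by the name of the read-out), a lower number less inhibition), reaching 100%. Compound 1 `FC(F)(F)c1ccc(Nc2nccc(-c3ccnc4ccccc34)n2)cc1` is close, giving 91.8%, a gap within the scatter. Compound 3 `Cc1nc2ccccn2c1-c1ccnc(Nc2ccc(C=O)s2)n1` falls far lower, giving 57.8%, and the step of a number 42.2 percentage points lower from compound 2 to compound 3 (beyond the scatter) shows how much a single change can move the read-out. Compound 4 `Cc1nc2ccccn2c1-c1ccnc(Nc2ccc(C(F)(F)F)cc2)n1` differs from compound 2 by trifluoromethyl in place of methyl on an aromatic carbon. For the measured compounds named here, no measured step matches this change directly; the only guide is that compound 1, which also carries trifluoromethyl but on a different core, sits within the scatter of compound 2. Compound 4 is therefore expected to stay near the top, with an estimated step of a number 5 percentage points lower from compound 2 to compound 4 (within the scatter). The estimate for compound 4 is 95%, ranging from 82% to 100%.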

Compound 4, a percentage reported as inhibition, at one concentration (the size of the read-out at that concentration, not a potency): 85.6%
For compound 4 the middle estimate is 9.4 percentage points above the measured one; the measured number falls inside the stated range.
By their numbers in this assay, from the lowest: compound 3; then compounds 4, 1 and 2 (each within the scatter of the next, the first and the last beyond it).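

For the compounds shown here, compound 2 and compound 4 give the first direct reading of this swap on one shared core: in this assay, replacing methyl with trifluoromethyl gives a number 14.4 percentage points lower from compound 2 to compound 4 (beyond the scatter). The position para to a large group therefore responds to this change, although the loss is modest and far from abolishing the read-out. Nothing measured here explains the drop.

Going by these compounds, how an amine or a carboxylic acid at this position would read remains open. So does whether the same swap would give a similar step on the core of compound 1.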